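This account rests on a few compounds, and the source may have more. Where it says the series, first, only, none or still open, it means among the compounds named here.

Measured so far in a functional assay on SK-BR-3 cells (Homo sapiens) for antiproliferative activity, read by CCK-8 assay, with a stated time of 72 h; a lower number here means a stronger inhibitor, a higher number a weaker inhibitor:
Compound 1 `Cc1cc(Nc2cc(N3CCN(C)CC3)nc(Nc3ccc(S(N)(=O)=O)cc3)n2)n[nH]1`: 15900 nM
Compound 2 `Cc1cc(Nc2cc(N3CCN(C)CC3)nc(Nc3ccc([N+](=O)[O-])cc3)n2)n[nH]1`: 437 nM

Of these two compounds, compound 2 has the lower number, 437 nM, which makes it the stronger inhibitor of the pair. The next compound to be tested is compound 3 `Cc1cc(Nc2cc(N3CCN(C)CC3)nc(Nc3ccc(Cl)cc3)n2)n[nH]1`, which differs from compound 2 at a single place: chloro in place of nitro on an aromatic carbon. This puts chloro in place of nitro on an aromatic carbon, para to a large group.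

Going by the values given here, only one measured step bears on this change: a 36-fold lower number from compound 1 to compound 2 (1.56 log units; beyond the scatter). There, nitro took the place of sulfamoyl on the same carbon. That large step shows that the group at this place can move the number a long way in this assay. Among the compounds with values here, it does not show how chloro ranks against nitro, and no measured compound carries chloro. A much smaller step than that one is therefore expected, leaning towards a somewhat higher number, and it may not clear the scatter. The estimated change is a 1.5-fold higher number from compound 2 to compound 3 (0.17 log units; within the scatter). For compound 3 the expected value is 650 nM, with an estimated range of 170 nM to 2500 nM.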

Compound 3, half-maximal inhibitory concentration: 1610 nM
Estimate against measurement, compound 3: 2.5-fold (0.39 log units) below, and the stated range covers the measured number.
By their numbers in this assay, from the lowest: compound 2; then compound 3; then compound 1.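

In this assay, chloro in place of nitro gives a 3.7-fold higher number from compound 2 to compound 3 (0.57 log units; beyond the scatter), so this position separates these two groups as well, and the 4-nitrophenyl of compound 2 keeps the lowest number of the three compounds. Chloro in place of sulfamoyl gives a 9.9-fold lower number from compound 1 to compound 3 (0.99 log units; beyond the scatter), which places compound 3 between the other two and gives a three-group order on this aromatic carbon, from the lowest number to the highest: nitro, chloro, sulfamoyl. The sulfamoyl of compound 1 is thus separated from both other groups by steps beyond the scatter, though no information here explains this order.

Going by these compounds alone, with only three groups compared, it remains open where others, such as an amine, a nitrile, a methoxy group or a carboxylic acid, would fall in this order on the same carbon. On these data alone, it is also open whether nitro would keep its place ahead of chloro if the shared core were changed elsewhere, since all three compounds carry that same core.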